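The compounds below may be only part of what the source reports. "The series", "measured", "known", "first", "only" and "open" are said of these compounds alone.

Measured compounds:
- compound 1, `COc1ccc(/C=C/S(=O)(=O)Nc2ccc(OC)cc2)cc1`: 5000 nM
- compound 2, `COc1cc(OC)c(/C=C/S(=O)(=O)Nc2ccc(OC)c(F)c2)c(OC)c1`: 75 nM
- compound 3, `COc1cc(OC)c(/C=C/S(=O)(=O)Nc2ccc(F)c([N+](=O)[O-])c2)c(OC)c1`: 75000 nM

In a functional assay on K562 cells (Homo sapiens) for cytotoxicity, read by trypan blue exclusion, with a stated time of 96 h (a higher number here means a weaker inhibitor, a lower number a stronger inhibitor), compound 2 gives the lowest of the three numbers; compound 1 gives a higher number and compound 3 a still higher one, both gaps beyond the usual scatter. Compound 2 is therefore the reference point of the series as it stands.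

Compound 4, `COc1cc(OC)c(/C=C/S(=O)(=O)Nc2ccc(OC)c(NC(C)C(=O)O)c2)c(OC)c1`, has not yet been measured in this assay. It differs from compound 2 in one place: (1-carboxyethyl)amino in place of fluoro on an aromatic carbon. Among the compounds with values here, no pair of measured compounds differs by a single change, so there is no measured step to lean on; the change itself is large, a single fluorine giving way to a six-heavy-atom chain carrying two hydrogen-bond donors and two acceptors.

For compound 4 the expectation is a higher number in this assay than compound 2, an estimated step of a 27-fold higher number from compound 2 to compound 4 (1.43 log units; beyond the scatter) beyond the scatter. The estimate for compound 4 is 2000 nM, with a range of 300 nM to 20000 nM.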

Compound 4, half-maximal inhibitory concentration: 8 nM
The estimate for compound 4 lay 250-fold (2.40 log units) above the measured number, outside the stated range (below it).
By their numbers in this assay, from the lowest: compound 4; then compound 2; then compound 1; then compound 3.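

In this assay, replacing fluoro with (1-carboxyethyl)amino on the aromatic carbon ortho to a methoxy group gives a 9.4-fold lower number from compound 2 to compound 4 (0.97 log units; beyond the scatter), a modest step. This position therefore accepts a substituent of six heavy atoms, with two hydrogen-bond donors and two hydrogen-bond acceptors, without any loss in this read-out, and the number falls instead. Nothing available explains why the number falls.

The compounds shown leave open which part of the (1-carboxyethyl)amino group matters, since a plain amine, an ester of the carboxylic acid or a longer chain ending in a carboxylic acid would each separate the nitrogen from the acid. They also leave open whether the methyl group on the chain contributes, which the simpler carboxymethylamino group would test.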